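The source may hold more compounds than are shown below. What is called first, only, known or untested is meant among the compounds shown, and "the series" means these compounds.

For the measured compounds named here, compound 2 `CNc1nc(NCC2CC2)cc(-c2ccccn2)n1` stands lowest of the two numbers so far in a functional assay on HEK293 cells for agonist activity at G-protein coupled receptor 39 (Mus musculus), read by inositol phosphate accumulation (a lower number here means that less compound is needed, a higher number that more compound is needed for the effect), at 115 nM; the only other point is compound 1 `CC(C)(C)CNc1nc(NCC2CC2)cc(-c2ccccn2)n1`, which in this assay gives 1500 nM. Going by the values given here, the one measured step, a 13-fold lower number from compound 1 to compound 2 (1.12 log units; beyond the scatter), removed tert-butyl from the saturated chain carbon bound to a nitrogen on the aromatic ring, so that nitrogen region is clearly sensitive. Compound 3 `CN(C)c1nc(NCC2CC2)cc(-c2ccccn2)n1` differs from compound 2 by methyl in place of hydrogen on a nitrogen on an aromatic ring. Among the compounds with values here, no measured step bears directly on substitution at the nitrogen itself, so the direction is open; a moderate loss is the working guess. The expected step is a 2.6-fold higher number from compound 2 to compound 3 (0.42 log units; beyond the scatter). Compound 3 is expected at 300 nM, range 80 nM to 2000 nM.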

Compound 3, half-maximal effective concentration: 6720 nM
Compound 3: middle estimate off by 22-fold (1.35 log units), on the low side; measured number outside the range, above it.
By their numbers in this assay, from the lowest: compound 2; then compound 1; then compound 3.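

In this assay, methyl in place of hydrogen on this nitrogen gives a 58-fold higher number from compound 2 to compound 3 (1.77 log units; beyond the scatter), and dimethylamino in place of neopentylamino gives a 4.5-fold higher number from compound 1 to compound 3 (0.65 log units; beyond the scatter), so among these three compounds, both with a hydrogen left on the nitrogen stand lower than the one without. The one-carbon methyl change thus moves the number in the opposite direction from the tert-butyl removal. Nothing on hand accounts for this loss.

Still open, going by these compounds, is whether the unsubstituted amine or ethylamino would match methylamino at this position, and whether a cyclic amine such as azetidine would behave like dimethylamino.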